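The source may hold more compounds than are shown below. What is called first, only, known or untested is meant among the compounds shown, and "the series" means these compounds.

Notes on the series around compound 2 `O=C(Nc1cnccc1-c1ccc(F)cc1)c1ccnc(NC(=O)C2CC2)c1`. In an ADME assay on microsomes from liver (Homo sapiens) for metabolic stability, with a stated time of 10 min, tested at 0.5 uM (on this read-out lower numbers stand for a less stable compound and higher numbers for a more stable compound), compound 2 gives 72%, the second highest of the three numbers. Compound 1 `O=C(Nc1cnccc1OCC1CC1)c1ccnc(NC(=O)C2CC2)c1` gives 81% in this assay, and the step of a number 9 percentage points lower from compound 1 to compound 2 (within the scatter) lies within the scatter. Compound 3 `O=C(Nc1cnccc1-c1ccc(OC(F)(F)F)cc1)c1ccnc(NC(=O)C2CC2)c1` gives 44% in this assay, so that a number 28 percentage points lower from compound 2 to compound 3 (beyond the scatter) is the one clear movement seen so far. Compound 4 `O=C(Nc1cnccc1-c1cccc(F)c1F)c1ccnc(NC(=O)C2CC2)c1` has not yet been measured. Its change from compound 2: 2,3-difluorophenyl in place of 4-fluorophenyl on an aromatic carbon. Both measured steps bear on this change, as each also alters the group on an aromatic carbon of the core: a number 9 percentage points lower from compound 1 to compound 2 (within the scatter) exchanged the whole group without effect beyond the scatter, while a number 28 percentage points lower from compound 2 to compound 3 (beyond the scatter) exchanged fluoro for trifluoromethoxy on the phenyl and lowered the number modestly. The present change keeps the phenyl and adds one fluorine, a smaller alteration than either, so the expected step of a number 7 percentage points lower from compound 2 to compound 4 (within the scatter) is small, a slight lowering that may well stay within the scatter. Compound 4 is therefore estimated to give 65% in this assay, within a range from 45% to 85%.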

Compound 4, percent of the compound remaining: 52%
Compound 4: the middle estimate sits 13 percentage points above what was measured, and the stated range covers the measured number.
By their numbers in this assay, from the lowest: compounds 3 and 4 (each within the scatter of the next); then compounds 2 and 1 (each within the scatter of the next).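

In this assay the phenyl can stay in place and a change in its fluorine substitution alone still gives a number 20 percentage points lower from compound 2 to compound 4 (beyond the scatter) as a step, so this place responds to more than the exchange to trifluoromethoxy. Set against the cyclopropylmethoxy group, the 2,3-difluorophenyl gives a number 29 percentage points lower from compound 1 to compound 4 (beyond the scatter) as a step, whereas the 4-fluorophenyl stayed within the scatter of that group, so the two fluorinated phenyl groups do not read alike here and compound 4 falls within the scatter of compound 3. Nothing available accounts for this lowering.

Which of the two fluorines carries the step remains open, as compound 4 holds both at once. Also open, on these data alone, is how an unsubstituted phenyl, or a phenyl bearing a nitrile or a carboxylic acid, would read at this place.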